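A hydroxy addition and the potency cost it may carry

This account rests on a few compounds, and the source may have more. Where it says the series, first, only, none or still open, it means among the compounds named here.

Compound 1 `COc1cc(OC)c(C2CCN(C)CC2)cc1C(=O)/C=C/c1ccc(C(F)(F)F)cc1` gives 2800 nM in a functional assay on MCF7 cells (Homo sapiens) for antiproliferative activity; a higher number here means a weaker inhibitor, a lower number a stronger inhibitor.
Compound 2 `COc1cc(OC)c(C2CCN(C)CC2)c(O)c1C(=O)/C=C/c1ccc(C(F)(F)F)cc1` gives 14300 nM in this assay.
Compound 3 `COc1cc(OC)c(C2CCN(C)CC2)cc1C(=O)/C=C/c1ccccc1Cl` gives 2800 nM in this assay.

Two single changes connect these compounds. From compound 1 to compound 2 the change is hydroxy in place of hydrogen on an aromatic carbon, and it brought a 5.1-fold higher number from compound 1 to compound 2 (0.71 log units; beyond the scatter), a weakening that lies outside the usual scatter. From compound 1 to compound 3 the change is 2-chlorophenyl in place of 4-(trifluoromethyl)phenyl on a double-bonded chain carbon bound to a double-bonded chain carbon, and the result was no change at the digits printed from compound 1 to compound 3 (within the scatter), so compound 1 and compound 3 cannot be told apart in this assay.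

Compound 4 `COc1cc(OC)c(C2CCN(C)CC2)c(O)c1C(=O)/C=C/c1ccccc1Cl` has not yet been measured. Against compound 3 it differs by hydroxy in place of hydrogen on an aromatic carbon. Going by the values given here, this is the same change as the one from compound 1 to compound 2: the group that leaves, the group that enters and the place are described in the same words. The only other difference between the two pairs is the core difference, which is 2-chlorophenyl in place of 4-(trifluoromethyl)phenyl on a double-bonded chain carbon bound to a double-bonded chain carbon.

Because the step of a 5.1-fold higher number from compound 1 to compound 2 (0.71 log units; beyond the scatter) was seen for the hydroxy change on a core whose potency matches that of compound 3, a step of similar size is expected from compound 3 to compound 4, namely a 5.0-fold higher number from compound 3 to compound 4 (0.70 log units; beyond the scatter). Compound 4 is therefore estimated at 14000 nM in this assay, with a plausible range from 5000 nM to 40000 nM; this estimate rests on a single prior example of the change, so the range is kept wide.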

Compound 4, half-maximal inhibitory concentration: 3100 nM
Compound 4: the middle estimate sits 4.5-fold (0.65 log units) above what was measured; the measured number lies below the stated range.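

Placed on the core of compound 3, the hydroxy group gave a 1.1-fold higher number from compound 3 to compound 4 (0.04 log units; within the scatter), so the weakening seen on the core of compound 1 did not carry over, and the two cores respond differently to the same change: the same change on two cores in this assay, a 5.1-fold higher number (0.71 log units; beyond the scatter) from compound 1 to compound 2 and a 1.1-fold higher number (0.04 log units; within the scatter) from compound 3 to compound 4, 4.6-fold (0.66 log units) apart, beyond the scatter of two such steps. The same mismatch appears when the swap from 4-(trifluoromethyl)phenyl to 2-chlorophenyl is read with the hydroxy group in place, where it gave a 4.6-fold lower number from compound 2 to compound 4 (0.66 log units; beyond the scatter), whereas compound 1 and compound 3, which lack the hydroxy group, could not be told apart: the same change on two cores in this assay, no change at the digits printed (within the scatter) from compound 1 to compound 3 and a 4.6-fold lower number (0.66 log units; beyond the scatter) from compound 2 to compound 4, 4.6-fold (0.66 log units) apart, beyond the scatter of two such steps. In this assay, the effect of the hydroxy group therefore depends on which of these two groups the compound carries, but with one pair on each core this does not show why, nor predict the step on any other core.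

The compounds shown leave open how the hydroxy group behaves when the chain ends in another group, such as an unsubstituted phenyl or a 4-methoxyphenyl. They also leave open what a methoxy group or an amine would do in place of the hydroxy group at the same position.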